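Selenium-sugar cytosine analogues: from azido to hydroxy

The source may hold more compounds than are shown below. What is called first, only, known or untested is meant among the compounds shown, and "the series" means these compounds.

Measured so far:
compound 1, `Cc1cn(C2[Se][C@H](CO)[C@@H](O)[C@@H]2N=[N+]=[N-])c(=O)[nH]c1=O`: > 100000 nM in a functional assay on SNU-638 cells (Homo sapiens) for cytotoxicity, read by sulforhodamine B assay; a higher number here means a weaker inhibitor, a lower number a stronger inhibitor
compound 2, `[N-]=[N+]=N[C@@H]1C(n2ccc(N)nc2=O)[Se][C@H](CO)[C@H]1O`: 85200 nM in this assay

Two compounds share a five-membered non-aromatic ring with one selenium, each carrying an azido group and a hydroxymethyl group on that ring. For compound 1 the value in this assay is a limit of the assay rather than a number, and (the limit of > 100000 nM in this assay, at which 1 of the 2 values shown sits). Within the data shown here, compound 2 is therefore the only compound with a number in this assay, and that number is a weak one.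

Compound 3, `Nc1ccn(C2[Se][C@H](CO)[C@@H](O)[C@@H]2O)c(=O)n1`, is not yet measured. It differs from compound 2 in one place: hydroxy in place of azido on a saturated ring carbon. Among the measured compounds shown here, no pair of measured compounds shows what such a change does in this assay, so there is no measured step to lean on. Compound 2 gives 85200 nM in this assay, and compound 3 is expected to sit close to it, with a step of a 1.1-fold higher number from compound 2 to compound 3 (0.02 log units; within the scatter) that may not exceed the scatter. Compound 3 is thus estimated at 90000 nM, between 20000 nM and 400000 nM, with a fair chance that only a limit is reported.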

Compound 3, half-maximal inhibitory concentration: 4720 nM
Beside the measured number, compound 3's estimate is 19-fold (1.28 log units) above it; the measured number lies below the stated range.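

Replacing azido with hydroxy on this saturated ring carbon, two ring bonds from the ring selenium, gives an 18-fold lower number from compound 2 to compound 3 (1.26 log units; beyond the scatter) in this assay and so shows that the group at this position can move the number well beyond the scatter. Before this, no measured step existed at all, and compound 2 alone held a number; the pair now shows that a weak value on the shared core is not fixed by the core itself, at least for this one change. Among these compounds, what lies behind the step is not told by anything measured here, and the single pair gives no cause for it.

Only azido and hydroxy are shown at this position, so it stays open whether an amine, a fluorine atom or a methoxy group there would read closer to compound 2 or to compound 3 in this assay. As far as these compounds go, it also stays open whether the same change would read alike on the core of compound 1, whose entry is a limit of the assay and not a number: the limit of > 100000 nM in this assay, at which 1 of the 3 values shown sits.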